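The compounds below may be only part of what the source reports. "The series", "measured", "known", "first", "only" and "open" are said of these compounds alone.

Compound 1, `O=C(CCl)N1CCCC(n2nc(-c3ccc(Oc4ccccc4)cc3)cc2CO)C1`, stands lowest of the three numbers in a functional assay on Z-138 cells (Homo sapiens) for inhibition, read by luminescence and CellTiter-Glo, with a stated time of 72 h (on this read-out higher numbers stand for weaker inhibition and lower numbers for stronger inhibition), where compound 1 gives 400 nM. Compound 2, `C/C=C/C(=O)N1CCCC(n2nc(-c3ccc(Oc4ccccc4)cc3)cc2CO)C1`, gives 51100 nM, and compound 3, `C/C=C/C(=O)Nc1cccc(Cn2nc(-c3ccc(Oc4ccccc4)cc3)cc2C(=O)OCC)c1`, gives 8900 nM. For the measured compounds named here, the one single-point step measured, a 130-fold higher number from compound 1 to compound 2 (2.11 log units; beyond the scatter), concerns the carbonyl substituent and not the change considered here. Compound 4, `CCOC(=O)c1cc(-c2ccc(Oc3ccccc3)cc2)nn1C1CCCN(C(=O)CCl)C1`, differs from compound 1 by ethoxycarbonyl in place of hydroxymethyl on an aromatic carbon. Going by the values given here, no measured step bears on this exchange; compound 3 carries the ethoxycarbonyl but differs from compound 1 elsewhere as well, so its value only hints at a weaker result. A modest increase is therefore expected, a 3.0-fold higher number from compound 1 to compound 4 (0.48 log units; beyond the scatter), with wide uncertainty. Compound 4 is estimated at 1200 nM, in a range from 300 nM to 5000 nM.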

Compound 4, half-maximal inhibitory concentration: 1300 nM
For compound 4 the middle estimate is 1.1-fold (0.03 log units) below the measured one, within the range that was stated.
By their numbers in this assay, from the lowest: compound 1; then compound 4; then compound 3; then compound 2.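

For the compounds shown here, exchanging hydroxymethyl for ethoxycarbonyl on this aromatic carbon gives a 3.3-fold higher number from compound 1 to compound 4 (0.51 log units; beyond the scatter) as a modest step, the first direct reading of this position. Inhibition persists when the hydrogen-bond donor of hydroxymethyl is lost and a larger group enters here. Nothing measured here explains why the number rises. Open, as far as these compounds go, is how a carboxylic acid or an aminomethyl group on this carbon would compare. Also open, from the compounds shown here alone, is whether this exchange would give a step of similar size with the prop-1-en-1-yl carbonyl of compound 2 in place of the chloromethyl carbonyl.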